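The source may report more compounds than this note shows. Statements on the series, on what has been measured and on what is new or still open speak of the compounds shown alone.

Measured compounds: compound 1 `Oc1ccc(-c2cc(-c3cccs3)cc(-c3ccc(O)cc3)n2)cc1` gives 11700 nM in a functional assay on T47D cells (Homo sapiens) for cytotoxicity, read by CCK-8 assay; on this read-out higher numbers stand for weaker inhibition and lower numbers for stronger inhibition; compound 2 `Oc1ccc(-c2cc(-c3ccco3)cc(-c3ccc(O)cc3)n2)cc1` gives 21100 nM in this assay; compound 3 `Oc1ccc(-c2cc(-c3ccoc3)cc(-c3ccccc3O)n2)cc1` gives only a limit of the assay, > 50000 nM, in this assay.

Compound 3 thus sits at the limit described by the limit of > 50000 nM in this assay, at which 1 of the 3 values shown sits, with no number of its own. The change to compound 4 `Oc1ccc(-c2cc(-c3ccoc3)cc(-c3ccc(O)cc3)n2)cc1` is 4-hydroxyphenyl in place of 2-hydroxyphenyl on an aromatic carbon. Within the data shown here, no measured step covers this change; the single measured step, a 1.8-fold higher number from compound 1 to compound 2 (0.26 log units; within the scatter), concerns a different group. Compounds 1 and 2, which carry two 4-hydroxyphenyl groups as compound 4 does, both give numbers within the range of this assay, while compound 3 does not. Compound 4 is therefore expected to give a number rather than a limit, estimated at 20000 nM (from 7000 nM to 50000 nM), a step of an at least 2.5-fold lower number from compound 3 to compound 4 (0.39 log units; beyond the scatter).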

Compound 4, half-maximal inhibitory concentration: 3460 nM
For compound 4 the middle estimate is 5.8-fold (0.76 log units) above the measured one; the whole stated range lies above it.
By their numbers in this assay, from the lowest: compound 4; then compounds 1 and 2 (each within the scatter of the next). At a limit, above all of these: compound 3.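

At the carbon next to the ring nitrogen, 4-hydroxyphenyl in place of 2-hydroxyphenyl gives an at least 14-fold lower number from compound 3 to compound 4 (1.15 log units; beyond the scatter), so two groups with the same atoms are clearly told apart at this position. Among these compounds, the group at the other position now also counts: furan-3-yl in place of furan-2-yl gives a 6.1-fold lower number from compound 2 to compound 4 (0.79 log units; beyond the scatter), and furan-3-yl in place of thiophen-2-yl gives a 3.4-fold lower number from compound 1 to compound 4 (0.53 log units; beyond the scatter), whereas the one earlier step lay within the scatter. The first of these steps starts from a limit of the assay, not a number: the limit of > 50000 nM in this assay, at which 1 of the 4 values shown sits.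

The compounds shown leave open how 3-hydroxyphenyl would compare at the first position and thiophen-3-yl at the second. They also leave open whether an amine or a carboxylic acid could replace the hydroxyl of 4-hydroxyphenyl.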